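Amine substituent change on the chloro-substituted anilino series

A few compounds are considered here, and "the series" means these few. Any claim that something is new, unique, unknown or untested is made for them only; others in the source may bear on it.

Going by the values given here, compound 2 `Clc1cc(-c2ccn3c(CC4CC4)nnc3c2Cl)ccc1NC1CC1` gives 6.1 nM in an assay on cells for binding affinity to metabotropic glutamate receptor 2 (Homo sapiens), read by scintillation proximity assay (on this read-out lower numbers stand for tighter binding and higher numbers for weaker binding), and holds the lowest of the two numbers measured so far. Among the compounds with values here, the only other compound, compound 1 `Fc1cc(-c2ccn3c(CC4CC4)nnc3c2Cl)ccc1NC1CC1`, gives 12.7 nM in this assay; the step of a 2.1-fold lower number from compound 1 to compound 2 (0.32 log units; beyond the scatter) is the single measured step and concerns chloro in place of fluoro on an aromatic carbon.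

Compound 3 `O[C@H]1CC[C@H](Nc2ccc(-c3ccn4c(CC5CC5)nnc4c3Cl)cc2Cl)CC1` is not yet measured. It differs from compound 2 by 4-hydroxycyclohexyl in place of cyclopropyl on a nitrogen on an aromatic ring; the same difference, cut one bond further out, reads cyclopropylamino to (4-hydroxycyclohexyl)amino. Within the data shown here, no measured step bears on this change: the one step known, a 2.1-fold lower number from compound 1 to compound 2 (0.32 log units; beyond the scatter), concerns a different place and leaves the substituent on the nitrogen untouched. The expectation therefore rests on nothing more than the starting point, and the estimate is set near compound 2 with a wide range. Compound 3 is estimated in this assay at 5 nM, between 1.5 nM and 20 nM. The expected step is a 1.2-fold lower number from compound 2 to compound 3 (0.09 log units; within the scatter), not beyond the scatter.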

Compound 3, dissociation constant: 12.7 nM
Compound 3: the middle estimate sits 2.5-fold (0.40 log units) below what was measured; the measured number falls inside the stated range.
By their numbers in this assay, from the lowest: compound 2; then compounds 1 and 3 (each within the scatter of the next).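

Notes on the substituent on the nitrogen: in this assay, the first measured change at this position, 4-hydroxycyclohexyl in place of cyclopropyl, gives a 2.1-fold higher number from compound 2 to compound 3 (0.32 log units; beyond the scatter), a modest step that is nonetheless beyond the scatter. The position therefore responds to this change but accepts a much larger substituent, 7 heavy atoms in place of 3 and carrying 1 hydrogen-bond donor and 1 hydrogen-bond acceptor, with compound 3 still at 12.7 nM. No supporting data tie the step to the ring size, the hydroxyl or the defined stereocentres of the entering group.

The compounds shown do not separate these features: a plain cyclohexyl, the other stereoisomer of 4-hydroxycyclohexyl or a 4-aminocyclohexyl on the same nitrogen would each bear on that question. They also leave open whether a 2.1-fold lower number from compound 1 to compound 2 (0.32 log units; beyond the scatter), seen with cyclopropyl on the nitrogen, carries over to the 4-hydroxycyclohexyl compounds, which would take the fluoro partner of compound 3 to show.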